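Bromo for chloro on the core of compound 1

This account rests on a few compounds, and the source may have more. Where it says the series, first, only, none or still open, it means among the compounds named here.

Going by the values given here, compound 1 `O=C1C(=O)N(CN(c2ccccc2)c2ccccc2)c2cccc(Cl)c21` is one of three compounds measured in a functional assay on MCF7 cells (Homo sapiens) for cytotoxicity, read by sulforhodamine B assay, with a stated time of 48 h; a higher number here means a weaker inhibitor of growth, a lower number a stronger inhibitor of growth; there compound 1 gives 29700 nM. Compound 3 `O=C1C(=O)N(CN2CCCCC2)c2cccc(Cl)c21`, which also carries chloro, gives 51200 nM in this assay, and compound 2 `CN(C)CN1C(=O)C(=O)c2c(Br)cccc21`, which carries bromo and a dimethylamino group, gives 57600 nM. Compound 1 has the lowest of the three numbers, but its gaps to compound 3 and to compound 2 both lie within the usual scatter, so no order among the three can be drawn from them.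

Compound 4 `O=C1C(=O)N(CN(c2ccccc2)c2ccccc2)c2cccc(Br)c21` differs from compound 1 in one place: bromo in place of chloro on an aromatic carbon. Among the compounds with values here, no pair of measured compounds shows this exchange on its own, so the size of the step is not fixed by the data. Since the exchange swaps one heavy atom for one heavy atom and the three measured numbers sit close together, the step from compound 1 to compound 4 is expected to be a 1.1-fold lower number from compound 1 to compound 4 (0.04 log units; within the scatter), not beyond the scatter in either direction. Compound 4 is therefore estimated at 27000 nM, with a range from 11000 nM to 65000 nM.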

Compound 4, concentration for 50% growth inhibition: 110000 nM
The estimate for compound 4 lay 4.1-fold (0.61 log units) below the measured number, outside the stated range (above it).
By their numbers in this assay, from the lowest: compounds 1, 3, 2 and 4 (each within the scatter of the next, the first and the last beyond it).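

In this assay, going by these compounds alone, bromo in place of chloro on this aromatic carbon gives a 3.7-fold higher number from compound 1 to compound 4 (0.57 log units; beyond the scatter) and is the only single-place exchange that can be read so far. The step is modest but lies beyond the scatter, so this position does not tolerate the change of one halogen for the other without a shift in the number, at least with the rest of compound 1 unchanged. Nothing at hand gives a reason for the step.

From the compounds shown here alone, whether the same exchange gives a similar step with the dimethylamino group of compound 2 or the side chain of compound 3 remains open. Also open, going by these compounds, is how fluoro, methyl, methoxy or plain hydrogen on this aromatic carbon would compare with chloro and bromo.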